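Hydroxyphenyl in place of trifluoromethylphenyl on the enaminone side

This account rests on a few compounds, and the source may have more. Where it says the series, first, only, none or still open, it means among the compounds named here.

Values measured in a functional assay on U-87MG ATCC cells (Homo sapiens) for antiproliferative activity, read by MTT assay, with a stated time of 48 h; a higher number here means a weaker inhibitor, a lower number a stronger inhibitor:
compound 1 `O=C(/C=C\Nc1ccc(O)cc1)c1cn(-c2ccccc2)nc1-c1ccccc1` gives 4290 nM
compound 2 `O=C(/C=C\Nc1ccc(O)cc1)c1cn(-c2ccccc2)nc1-c1ccc(F)cc1` gives 4700 nM
compound 3 `O=C(/C=C\Nc1ccc(C(F)(F)F)cc1)c1cn(-c2ccccc2)nc1-c1ccc(Cl)cc1` gives > 50000 nM

Among the compounds with values here, compound 3 stands only at a limit: in this assay compound 3 reaches > 50000 nM, which is a limit of the assay and not a number, the one value of the three that sits at the limit of > 50000 nM in this assay, at which 1 of the 3 values shown sits.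

Compound 4 `O=C(/C=C\Nc1ccc(O)cc1)c1cn(-c2ccccc2)nc1-c1ccc(Cl)cc1` has not been measured. It differs from compound 3 in one place: hydroxy in place of trifluoromethyl on an aromatic carbon.

Within the data shown here, only one measured step exists in the set, a 1.1-fold higher number from compound 1 to compound 2 (0.04 log units; within the scatter), and it concerns a different part of the molecule, the phenyl attached to the shared core. Among the measured compounds shown here, no measured step covers the exchange of trifluoromethyl for hydroxy. What the numbers do show is that compound 1 and compound 2, both carrying the hydroxyphenyl group that compound 4 also carries, return numbers of similar size, while compound 3 with the trifluoromethyl group sits at the limit. Compound 4 is therefore expected to move from the limit to a measurable number; the expected step is an at least 9.0-fold lower number from compound 3 to compound 4 (0.95 log units; beyond the scatter). The estimate for compound 4 in this assay is 5500 nM, with a range from 2000 nM to 16000 nM.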

Compound 4, half-maximal inhibitory concentration: 1500 nM
Compound 4: middle estimate off by 3.7-fold (0.56 log units), on the high side; the whole stated range lies above it.
By their numbers in this assay, from the lowest: compound 4; then compounds 1 and 2 (each within the scatter of the next). At a limit, above all of these: compound 3.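

In this assay, hydroxy in place of trifluoromethyl on the aromatic carbon of the enaminone-side phenyl gives an at least 33-fold lower number from compound 3 to compound 4 (1.52 log units; beyond the scatter), the only step shown at this position, and it separates a measurable number from no measurable number. Compound 3 stands at a limit of the assay and not at a number, so this step has a bound and no exact size: the limit of > 50000 nM in this assay, at which 1 of the 4 values shown sits. The phenyl attached to the shared core, flat with fluoro at a 1.1-fold higher number from compound 1 to compound 2 (0.04 log units; within the scatter), does respond to chloro, with a 3.1-fold lower number from compound 2 to compound 4 (0.50 log units; beyond the scatter) and a 2.9-fold lower number from compound 1 to compound 4 (0.46 log units; beyond the scatter).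

Going by these compounds, how a methoxy or an amine at the hydroxy position would compare remains open, as does whether any group other than hydroxy gives a measurable number there. Also open, on these data alone, is whether bromo or methyl on the core-attached phenyl would follow chloro or fluoro.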